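Same Methoxy Step Tried on a Second Core

The compounds below may be only part of what the source reports. "The series", "measured", "known", "first", "only" and "open" are said of these compounds alone.

Of the compounds shown here, three in this set have been measured in a physicochemical assay for lipophilicity, read by LC-MS, in phosphate buffer, measured as octanol-water partition, with a stated time of 1 h, at pH 7.4; a higher number here means a more lipophilic compound, a lower number a more polar compound. Compound 1 `C[C@H](Nc1cc(F)c(S(=O)(=O)Nc2cscn2)cc1Cl)c1ccccc1F` gives 3.5. Compound 2 `COc1ccc(F)c([C@H](C)Nc2cc(F)c(S(=O)(=O)Nc3cscn3)cc2Cl)c1` gives 3.4 in this assay. The difference between them, (methoxy in place of hydrogen on an aromatic carbon), made a step of a number 0.10 log units lower from compound 1 to compound 2 (within the scatter). Compound 3 `C[C@H](Nc1cc(F)c(S(=O)(=O)Nc2cscn2)c(F)c1)c1ccccc1F` gives 2.9 in this assay, the lowest of the three numbers; how the core of compound 3 differs from the core of compound 1 is not broken down here. Compound 4 `COc1ccc(F)c([C@H](C)Nc2cc(F)c(S(=O)(=O)Nc3cscn3)c(F)c2)c1` has not yet been measured. It differs from compound 3 by methoxy in place of hydrogen on an aromatic carbon, and the place of this change reads word for word as it does for the change from compound 1 to compound 2, so it is the same change carried onto a different core. Because that earlier step was a number 0.10 log units lower from compound 1 to compound 2 (within the scatter), the step from compound 3 to compound 4 is expected to be a number 0.10 log units lower from compound 3 to compound 4 (within the scatter), an expectation resting on that single prior instance. Compound 4 is therefore estimated at 2.8, between 2.4 and 3.2.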

Compound 4, distribution coefficient: 2.9
Compound 4: middle estimate off by 0.10 log units, on the low side; the measured number falls inside the stated range.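

In this assay, the change from 2-fluorophenyl to 2-fluoro-5-methoxyphenyl gives no change at the digits printed from compound 3 to compound 4 (within the scatter) on one core and a number 0.10 log units lower from compound 1 to compound 2 (within the scatter) on the other, so the step lies within the scatter on both cores shown. This is only two instances of the same change on two cores, and it shows nothing about a third core, about methoxy at another place on the ring, or about any other kind of measurement. Nothing in the data shown gives a reason for this result.

The compounds shown leave open whether a group other than methoxy on the same aromatic carbon, such as an amine, a carboxylic acid or a longer chain like butoxy, would also give a step within the scatter on both cores. They also leave open whether such a group would give steps of the same size on the two cores, as the methoxy steps do within the scatter.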